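Ether side chain variation across three analogues

The compounds below may be only part of what the source reports. "The series", "measured", "known", "first", "only" and "open" are said of these compounds alone.

Compound 1 `COCC(C)Oc1cccc2ccc(N)nc12` and compound 2 `CCCCCOc1cccc2ccc(N)nc12` share one core and differ only in the group on the oxygen on the aromatic ring. In an assay on cells with melanin-concentrating hormone receptor 1 (Homo sapiens) as the target, read by radioligand binding (a higher number here means a weaker inhibitor, a lower number a stronger inhibitor), compound 1 gives 606 nM and compound 2 gives 580 nM. Among the compounds with values here, the single measured step, a 1.0-fold lower number from compound 1 to compound 2 (0.02 log units; within the scatter), lies within the scatter, so compound 2 holds the lower of the two numbers without standing apart from compound 1. Compound 3 `CCC#CCOc1cccc2ccc(N)nc12` carries but-1-yn-1-yl in place of butyl on a saturated chain carbon bound to an oxygen on an aromatic ring; the same difference, read one bond further out, is pentyl to pent-2-yn-1-yl. Within the data shown here, no measured step tests a triple bond in this chain; the one step available shows that exchanging one ether chain for another gave a step within the scatter in this assay. On that basis no step beyond the scatter is expected, a 1.0-fold higher number from compound 2 to compound 3 (0.01 log units; within the scatter). Compound 3 is therefore expected to give about 600 nM in this assay, with a range from 250 nM to 1500 nM.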

Compound 3, half-maximal inhibitory concentration: > 2000 nM
Compound 3: no number, only a limit; the forecaster's own chance of this, stated with the estimate: 5%; at least 3.3-fold (0.52 log units) between middle value and limit.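

In this assay compound 3 carries a limit and not a number: the limit of > 2000 nM in this assay, at which 1 of the 3 values shown sits.

Even so, the change on a saturated chain carbon bound to an oxygen on an aromatic ring gives an at least 3.4-fold higher number from compound 2 to compound 3 (0.53 log units; beyond the scatter), and the exchange of the whole ether side chain gives an at least 3.3-fold higher number from compound 1 to compound 3 (0.51 log units; beyond the scatter). Within the data shown here, the earlier pair suggested that this position accepts different ether chains, but compound 3 shows that it does not accept all of them: among the three compounds, the chain with the triple bond is the only one whose steps lie beyond the scatter.

Going by these compounds, how far the true value of compound 3 lies past its limit remains open, so only the minimum size of both steps is known. Also open, on these data alone, is whether the triple bond itself or its location in the chain matters, which a pent-2-en-1-yl chain, a propyl chain or a chain carrying an amine could help to separate.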